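This account rests on a few compounds, and the source may have more. Where it says the series, first, only, none or still open, it means among the compounds named here.

Measured so far:

Compound 1 `CC1=C(/C=C/C(=O)/C=C/c2ccccc2)C(C)(C)CCC1`: 10600 nM
Compound 2 `CC1=C(/C=C/C(=O)/C=C/c2ccc(C)cc2)C(C)(C)CCC1`: 23800 nM

Of the two compounds measured in a functional assay on MCF7 cells (Homo sapiens) for cytotoxicity, read by sulforhodamine B assay, with a stated time of 48 h (on this read-out lower numbers stand for stronger inhibition and higher numbers for weaker inhibition), compound 2 gives the higher number, 23800 nM, and its nearest neighbour is compound 1 at 10600 nM. Going by the values given here, the single measured step, a 2.2-fold higher number from compound 1 to compound 2 (0.35 log units; beyond the scatter), is the only guide available, and it shows that putting a methyl on the aromatic ring moved the number upward by a modest amount.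

Compound 3 `CC1=C(/C=C/C(=O)/C=C/c2cccnc2)C(C)(C)CCC1` is not yet measured in this assay. It differs from compound 2 in one place: pyridin-3-yl in place of 4-methylphenyl on a double-bonded chain carbon bound to a double-bonded chain carbon. Part of this change undoes the methyl that was added in going from compound 1 to compound 2; the rest, the exchange of a carbon ring for a ring holding one nitrogen, has no counterpart among the measured pairs, so its effect is unknown. Among the compounds with values here, on the one step that does bear on it, the methyl removal is expected to bring the number back toward that of compound 1, while the ring nitrogen adds uncertainty in either direction. Compound 3 is therefore expected to show a step of a 2.0-fold lower number from compound 2 to compound 3 (0.30 log units; within the scatter) in this assay. The estimated value of compound 3 is 12000 nM, with a range from 5000 nM to 30000 nM.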

Compound 3, half-maximal inhibitory concentration: 15500 nM
Beside the measured number, compound 3's estimate is 1.3-fold (0.11 log units) below it; the measured number falls inside the stated range.
By their numbers in this assay, from the lowest: compounds 1, 3 and 2 (each within the scatter of the next, the first and the last beyond it).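

In this assay, pyridin-3-yl on a double-bonded chain carbon bound to a double-bonded chain carbon gives the first ring at this place that holds a nitrogen, and the numbers stay close to those of the carbon rings: the exchange for 4-methylphenyl gives a 1.5-fold lower number from compound 2 to compound 3 (0.19 log units; within the scatter), and the exchange for phenyl gives a 1.5-fold higher number from compound 1 to compound 3 (0.17 log units; within the scatter). Neither step separates compound 3 from the compound it is compared with, so a ring nitrogen at this place, with its one hydrogen-bond acceptor, shows no measurable gain or loss in this read-out. Compound 3 also cannot be ranked against the other two, although those two lie beyond the scatter of each other, and no trend across the three rings can be claimed.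

The compounds shown leave open whether the nitrogen matters elsewhere in the ring, as in pyridin-2-yl or pyridin-4-yl, and whether a ring carrying an amine or a carboxylic acid would move the number beyond the scatter. Nothing at hand explains the numbers seen for these three compounds.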